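Benzyl for Cyclohexyl on the Ring Nitrogen

The compounds below may be only part of what the source reports. "The series", "measured", "known", "first", "only" and "open" are said of these compounds alone.

Measured compounds:
compound 1, `COc1ccc(-n2sc(=O)n(-c3ccc(OC)cc3)c2=O)cc1`: < 2000 nM
compound 2, `COc1ccc(-n2sc(=O)n(C3CCCCC3)c2=O)cc1`: < 2000 nM
compound 3, `O=c1sn(-c2ccccc2)c(=O)n1-c1ccccc1`: < 2000 nM

Of the compounds shown here, three sharing one core have been measured in an ADME assay, in phosphate buffer, with a stated time of 30 min, tested at 1 mM, at a dose of 1 mM; a lower number here means less compound in the circulation, a higher number more compound in the circulation at the dose given. In this assay compound 1 gives < 2000 nM, which is a limit of the assay and not a number. Compound 2 gives < 2000 nM, again a limit. Compound 3 gives < 2000 nM, also a limit. All three readings therefore sit at the limit of < 2000 nM in this assay, at which 3 of the 3 values shown sit, so compound 2 cannot be placed above or below compound 1 or compound 3; it stands where every value shown stands, at the limit.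

Compound 4, `COc1ccc(-n2sc(=O)n(Cc3ccccc3)c2=O)cc1`, has not been measured. It differs from compound 2 by benzyl in place of cyclohexyl on an aromatic nitrogen. Within the data shown here, no step between measured compounds is available to calibrate this change. Since compound 1, compound 2 and compound 3 all rest at the same limit, the step from compound 2 to compound 4 is expected to be none beyond the scatter, as a step that the limit leaves unreadable from compound 2 to compound 4. Compound 4 is thus expected to give about 1000 nM in this assay, with a range from 300 nM to 2500 nM, and most likely another limit reading.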

Compound 4, maximal plasma concentration: 5490 nM
Estimate against measurement, compound 4: 5.5-fold (0.74 log units) below, outside the stated range (above it).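

Among these compounds, compound 4 is the first compound here to give a reading in this assay that is a number and not a limit, which shows that the group on this aromatic nitrogen can change the maximal plasma concentration. The change from cyclohexyl to benzyl brings an at least 2.7-fold higher number from compound 2 to compound 4 (0.43 log units; beyond the scatter), and its full size cannot be read because one end of the step rests on a limit: the limit of < 2000 nM in this assay, at which 3 of the 4 values shown sit.

Neither group carries a hydrogen-bond donor, a hydrogen-bond acceptor or a net charge, so this step comes with no change in those counts.

As far as these compounds go, it remains open whether the higher reading belongs to the aromatic ring of benzyl or to the carbon that joins that ring to the nitrogen, and a phenethyl chain, or a benzyl group bearing an amine or a carboxylic acid, would test how far the change extends. From the compounds shown here alone, it is also open whether benzyl gives a step of similar size when the methoxy group on the other aromatic ring of the shared core is replaced by another group.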